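A methyl-for-hydrogen swap on two related cores

A few compounds are considered here, and "the series" means these few. Any claim that something is new, unique, unknown or untested is made for them only; others in the source may bear on it.

Compound 1 `CCn1c(/C=C2/C(=O)Nc3ccc(F)cc32)nc2ccccc21` and compound 2 `CC(C)n1c(/C=C2/C(=O)Nc3ccc(F)cc32)nc2ccccc21` share one core, while compound 3 `Cn1c(/C=C2/C(=O)Nc3ccc(Cl)cc32)nc2ccccc21` and the unmeasured compound 4 `CCn1c(/C=C2/C(=O)Nc3ccc(Cl)cc32)nc2ccccc21` share another; the difference between the two cores is not broken down here. In a functional assay on A549 cells (Homo sapiens) for cytotoxicity, read by MTT assay, with a stated time of 48 h (on this read-out lower numbers stand for stronger inhibition and higher numbers for weaker inhibition), compound 1 gives only a limit, > 50000 nM, at the limit of > 50000 nM in this assay, at which 1 of the 3 values shown sits. Compound 2 gives 28500 nM in this assay. The change between them is methyl in place of hydrogen on a saturated chain carbon bound to an aromatic nitrogen and a saturated chain carbon, and it made an at least 1.7-fold lower number from compound 1 to compound 2 (0.24 log units; that floor lies within the scatter). Compound 3 gives 39700 nM in this assay. Compound 4 differs from compound 3 by methyl in place of hydrogen on a saturated chain carbon bound to an aromatic nitrogen; this is the same kind of change, but the place differs, being bound only to an aromatic nitrogen rather than to an aromatic nitrogen and a saturated chain carbon. Since the earlier step was an at least 1.7-fold lower number from compound 1 to compound 2 (0.24 log units; that floor lies within the scatter) and compound 1 sits at a limit, the step expected here is a 1.1-fold lower number from compound 3 to compound 4 (0.04 log units; within the scatter), which lies within the usual scatter. Compound 4 is therefore estimated at 36000 nM, between 15000 nM and 85000 nM.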

Compound 4, half-maximal inhibitory concentration: > 50000 nM
Compound 4 ended at the assay's limit (the forecaster's own chance of this, stated with the estimate: 35%); at least 1.3-fold (0.14 log units) between middle value and limit.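

In this assay, the methyl-for-hydrogen swap on the second core gives an at least 1.2-fold higher number from compound 3 to compound 4 (0.10 log units; that floor lies within the scatter). The value of compound 4 is a limit rather than a number, as is that of compound 1, so the step between them, chloro in place of fluoro, cannot be read: the limit of > 50000 nM in this assay, at which 2 of the 4 values shown sit. The result therefore shows neither that the change carries over from one core to the other nor that it fails to: the same change on two cores in this assay, an at least 1.7-fold lower number (0.24 log units; that floor lies within the scatter) from compound 1 to compound 2 and an at least 1.2-fold higher number (0.10 log units; that floor lies within the scatter) from compound 3 to compound 4; the limit leaves it open whether they differ.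

The compounds shown leave open how far compound 1 and compound 4 lie beyond the limit. They also leave open whether a longer chain, such as butyl, or an amine on the chain would give a lower number on either core.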